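Series notes: aryl-tail variation on the imidazole side chain

A few compounds are considered here, and "the series" means these few. Any claim that something is new, unique, unknown or untested is made for them only; others in the source may bear on it.

Compounds measured so far:
- compound 1, `O=C(O)c1ccccc1-c1ccc(CCc2ncc(CC3CCCCCC3)[nH]2)cc1`: 5.7 nM in an in vitro functional assay on cells for agonist activity at Bombesin receptor subtype-3 (Mus musculus), read by luminescence and calcium flux; on this read-out higher numbers stand for an effect only at larger amounts of compound and lower numbers for an effect already at smaller amounts
- compound 2, `O=C(O)c1ccccc1-c1ccc(CCc2ncc(CCc3ccccc3)[nH]2)cc1`: 174 nM in this assay

Within the data shown here, compound 2 holds the highest of the two numbers so far; its only neighbour is compound 1, reached by the step of a 31-fold higher number from compound 1 to compound 2 (1.48 log units; beyond the scatter), which is large and well beyond the scatter.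

Compound 3, `O=C(O)c1ccccc1-c1ccc(CCc2ncc(Cc3ccccc3Cl)[nH]2)cc1`, has not yet been measured. It differs from compound 2 by the change (2-chlorophenyl in place of benzyl on a saturated chain carbon bound to an aromatic carbon).

Among the measured compounds shown here, the one measured step, a 31-fold higher number from compound 1 to compound 2 (1.48 log units; beyond the scatter), replaces the whole group on that saturated chain carbon and does not isolate the effect of a chlorine on the ring or of shortening the chain, so it gives only weak guidance here. For the measured compounds named here, with no closer precedent, the expectation for compound 3 in this assay is a step of a 1.5-fold lower number from compound 2 to compound 3 (0.16 log units; within the scatter) from compound 2, a modest lowering of the number, uncertain in direction within a wide range: estimated at 120 nM, between 30 nM and 500 nM.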

Compound 3, half-maximal effective concentration: 22 nM
Compound 3: the middle estimate sits 5.5-fold (0.74 log units) above what was measured; the whole stated range lies above it.
By their numbers in this assay, from the lowest: compound 1; then compound 3; then compound 2.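

In this assay an aromatic tail at this position need not give a high number: the result is a 7.9-fold lower number from compound 2 to compound 3 (0.90 log units; beyond the scatter) and so shows that the position tolerates more than compound 2 suggested. Cycloheptyl remains ahead of 2-chlorophenyl on this saturated chain carbon bound to an aromatic carbon, with a 3.9-fold higher number from compound 1 to compound 3 (0.59 log units; beyond the scatter) as the remaining gap. Read one bond further out, the change is phenethyl to 2-chlorobenzyl, so chain and chlorine change together, and no supporting data explain the step.

The compounds shown do not separate the chlorine from the change in chain, so a plain benzyl tail on the imidazole side chain remains the open comparison. Also open, as far as these compounds go, is whether a fluorine or a methoxy group in place of the chlorine gives a similar number.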